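A few compounds are considered here, and "the series" means these few. Any claim that something is new, unique, unknown or untested is made for them only; others in the source may bear on it.

In an ADME assay on the whole organism (plasma, Mus musculus, strain CD-1) for protein binding, read by LC-MS, with a stated time of 24 h (a higher number here means a larger unbound share of the compound, a lower number a smaller unbound share), compound 2 `Cc1noc(-c2ccc(O[C@H]3CCC[C@H](C(=O)O)C3)cc2)c1CNC(=O)OCc1ccccc1` gives 0.007 and compound 1 `Cc1noc(-c2ccc(O[C@H]3CCC[C@H](C(=O)O)C3)cc2)c1COC(=O)N(C)CCC(C)C` gives 0.004, two values within the scatter of each other. Compound 3 `Cc1noc(-c2ccc(O[C@H]3CCC[C@H](C(=O)O)C3)cc2)c1COC(=O)N(C)C1CCCC1` differs from compound 2 by a group of 10 heavy atoms (7 carbon, 1 nitrogen, 2 oxygen; one five-membered non-aromatic ring of carbon only) in place of a group of 11 heavy atoms (8 carbon, 1 nitrogen, 2 oxygen; one six-membered aromatic ring of carbon only), on a saturated chain carbon bound to an aromatic carbon. Going by the values given here, one measured step bears on this change: a 1.8-fold higher number from compound 1 to compound 2 (0.24 log units; within the scatter), also an exchange of the group on a saturated chain carbon bound to an aromatic carbon, and it lies within the scatter. In this assay, only a small step towards a lower number, within the scatter, is therefore expected. The estimated step is a 1.4-fold lower number from compound 2 to compound 3 (0.15 log units; within the scatter). For compound 3 the expected value is 0.005, with an estimated range of 0.0025 to 0.01.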

Compound 3, unbound fraction: 0.006
The estimate for compound 3 lay 1.2-fold (0.08 log units) below the measured number, within the range that was stated.
By their numbers in this assay, from the lowest: compounds 1, 3 and 2 (each within the scatter of the next).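

In this assay, cyclopentyl in place of isopentyl on the amide-type nitrogen gives a 1.5-fold higher number from compound 1 to compound 3 (0.18 log units; within the scatter), and the exchange of the (benzyloxycarbonyl)amino group gives a 1.2-fold lower number from compound 2 to compound 3 (0.07 log units; within the scatter). At this position, an open chain, a non-aromatic ring and an aromatic ring, with or without the hydrogen-bond donor, are thus separated by no step beyond the scatter. No measured evidence accounts for these steps.

Still open, on these data alone, is whether a morpholine or other amine at this position gives a step beyond the scatter. Also open, as far as these compounds go, is what a tetrazole in place of the carboxylic acid would do.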